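The compounds below may be only part of what the source reports. "The series", "measured", "known", "first", "only" and "open" are said of these compounds alone.

In a functional assay, read by spectrophotometry, with a stated time of 30 min (a lower number here means that less compound is needed, a higher number that more compound is needed for the effect), compound 1 (`O=C(/C=C/c1ccc(O)c(O)c1)N1CCN(S(=O)(=O)c2cccc3cnccc23)CC1`) gives 9930 nM and stands level with its two measured relatives, compound 2 (`O=C(CCc1ccc(O)c(O)c1)N1CCN(S(=O)(=O)c2cccc3cnccc23)CC1`) at 10100 nM and compound 3 (`O=C(CCc1ccc(O)c(O)c1)N1CCCN(S(=O)(=O)c2cccc3cnccc23)CC1`) at 9680 nM. Compound 4 (`COc1cc(/C=C/C(=O)N2CCN(S(=O)(=O)c3cccc4cnccc34)CC2)ccc1O`) turns the 3,4-dihydroxyphenyl of compound 1 into 4-hydroxy-3-methoxyphenyl, with methyl in place of hydrogen on an oxygen on an aromatic ring. Within the data shown here, only one measured step bears on this even indirectly: 2-(3,4-dihydroxyphenyl)ethyl in place of 2-(3,4-dihydroxyphenyl)ethenyl (a 1.0-fold higher number from compound 1 to compound 2 (0.01 log units; within the scatter)) stays within the scatter, but it leaves the 3,4-dihydroxyphenyl untouched. All three measured compounds carry that group, so the data hold no direct measure of hydroxy to methoxy. Among the measured compounds shown here, the change alters the one group they all share. A move to a higher number beyond the scatter is expected, as a judgement rather than a measured trend. The estimated step is moderate (a 3.0-fold higher number from compound 1 to compound 4 (0.48 log units; beyond the scatter)). The expected value for compound 4 is 30000 nM in a range from 12000 nM to 100000 nM by this estimate.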

Compound 4, half-maximal effective concentration: 6420 nM
Compound 4: middle estimate off by 4.7-fold (0.67 log units), on the high side, outside the stated range (below it).
By their numbers in this assay, from the lowest: compounds 4, 3, 1 and 2 (each within the scatter of the next).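

Methyl in place of hydrogen on an oxygen on an aromatic ring is the first change here to touch the 3,4-dihydroxyphenyl shared by the earlier compounds, and in this assay it gives a 1.5-fold lower number from compound 1 to compound 4 (0.19 log units; within the scatter). For this one pair, then, the free hydroxy at that place can become methoxy without a shift beyond the usual scatter, so that hydroxy is not required for the effect at the level measured here. Nothing measured for these compounds gives a reason for this result.

The compounds shown leave open whether the remaining hydroxy would bear the same change, and whether an ethoxy group or an amine would be accepted in place of either hydroxy. They also leave open whether the 4-hydroxy-3-methoxyphenyl would read the same on the cores of compound 2 and compound 3.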